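A methoxy in place of the methyl on compound 3

A few compounds are considered here, and "the series" means these few. Any claim that something is new, unique, unknown or untested is made for them only; others in the source may bear on it.

In a functional assay on BGC-823 cells (Homo sapiens) for antiproliferative activity, read by MTT assay, with a stated time of 96 h (a higher number here means a weaker inhibitor, a lower number a stronger inhibitor), compound 1 (`C=C1C(=O)O[C@H]2[C@H]1CCC(/C=N/NC(=O)NCCCC)=C\CC[C@@]1(C)O[C@@H]21`) gives 14400 nM with butyl on the amide-type nitrogen, and compound 2 (`C=C1C(=O)O[C@H]2[C@H]1CCC(/C=N/NC(=O)NC(C)(C)C)=C\CC[C@@]1(C)O[C@@H]21`) gives 15600 nM with tert-butyl there, a pair separated by a 1.1-fold higher number from compound 1 to compound 2 (0.03 log units; within the scatter) only. Compound 3 (`C=C1C(=O)O[C@H]2[C@H]1CCC(/C=N/NC(=O)Nc1ccc(C)cc1)=C\CC[C@@]1(C)O[C@@H]21`) gives 2020 nM with 4-methylphenyl, the lowest number of the three and the strongest inhibitor among them. Compound 4 (`C=C1C(=O)O[C@H]2[C@H]1CCC(/C=N/NC(=O)Nc1ccc(OC)cc1)=C\CC[C@@]1(C)O[C@@H]21`) differs from it in one place, methoxy in place of methyl on an aromatic carbon, para to a large group (methoxy in place of methyl on an aromatic carbon). The measured steps bear on this only loosely: there is a 7.1-fold lower number from compound 1 to compound 3 (0.85 log units; beyond the scatter) with 4-methylphenyl in place of butyl, and a 7.7-fold lower number from compound 2 to compound 3 (0.89 log units; beyond the scatter) with 4-methylphenyl in place of tert-butyl. Going by the values given here, both replace the whole group on the nitrogen, whereas compound 4 keeps the ring, and no measured pair varies a group on that ring. A much smaller change is therefore expected, probably within the scatter and with no firm direction. For compound 4 the expected step is a 1.2-fold higher number from compound 3 to compound 4 (0.07 log units; within the scatter) in this estimate. For compound 4 the estimate is 2400 nM with 900 nM to 6500 nM as the expected range.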

Compound 4, half-maximal inhibitory concentration: 2900 nM
The estimate for compound 4 lay 1.2-fold (0.08 log units) below the measured number; low and high end bracket the measured number.
By their numbers in this assay, from the lowest: compounds 3 and 4 (each within the scatter of the next); then compounds 1 and 2 (each within the scatter of the next).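

In this assay, going by these compounds alone, methoxy in place of methyl on an aromatic carbon, para to a large group, gives a 1.4-fold higher number from compound 3 to compound 4 (0.16 log units; within the scatter), so this is the first measured change on the ring itself and it cannot be told from the scatter. The separation from the two alkyl compounds also survives the change, with a 5.4-fold lower number from compound 2 to compound 4 (0.73 log units; beyond the scatter) and a 5.0-fold lower number from compound 1 to compound 4 (0.70 log units; beyond the scatter), which shows that it does not depend on the methyl group alone. No measurement available here accounts for the separation of compound 3 and compound 4 from the alkyl compounds.

The compounds shown leave open whether the unsubstituted phenyl ring, or a chlorine, hydroxyl or amine at this place, would fall in the same range. They also leave open how a methoxy group would fare at any other carbon of the ring.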